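Adding a second carboxy group to compound 3

The source may hold more compounds than are shown below. What is called first, only, known or untested is meant among the compounds shown, and "the series" means these compounds.

Measured in a functional assay on MCF7 cells (Homo sapiens) for antiproliferative activity, read by MTT assay, with a stated time of 24 h (on this read-out higher numbers stand for weaker inhibition and lower numbers for stronger inhibition), each value a limit and not a number:

- compound 1 `CCn1c(C(=O)NCC(=O)OC)ccc1C(CC)(CC)c1ccc(OCS(=O)(=O)c2ccccc2)c(C)c1`: > 50000 nM
- compound 2 `CCn1c(C(=O)N[C@@H](CC(=O)OC)C(=O)OC)ccc1C(CC)(CC)c1ccc(OCS(=O)(=O)c2ccccc2)c(C)c1`: > 50000 nM
- compound 3 `CCn1c(C(=O)N[C@H](C)C(=O)O)ccc1C(CC)(CC)c1ccc(OCS(=O)(=O)c2ccccc2)c(C)c1`: > 50000 nM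

In this assay compound 3 gives > 50000 nM, which is a limit. It holds no rank of its own, as all three compounds share one ceiling: the limit of > 50000 nM in this assay, at which 3 of the 3 values shown sit.

Compound 4 `CCn1c(C(=O)N[C@H](CC(=O)O)C(=O)O)ccc1C(CC)(CC)c1ccc(OCS(=O)(=O)c2ccccc2)c(C)c1` differs from compound 3 by carboxy in place of hydrogen on a saturated chain carbon, two bonds along the chain from an amide-type nitrogen and a carbonyl carbon. This places carboxy in place of hydrogen on a saturated chain carbon, two bonds along the chain from an amide-type nitrogen and a carbonyl carbon, so that 1-carboxyethyl becomes 1,2-dicarboxyethyl.

Going by the values given here, three measured steps bear on this change. The closest also adds a side branch, there in ester form: a step that the two limits leave unreadable from compound 1 to compound 2. The other two change the group on the amide-type nitrogen: a step that the two limits leave unreadable from compound 1 to compound 3 and a step that the two limits leave unreadable from compound 2 to compound 3. Among the compounds with values here, none of them gives a size or a direction, and no measured compound shows a number to work from. The expected result is a step that the limit leaves unreadable from compound 3 to compound 4, with no direction expected and nothing beyond the scatter. A further limit is the likeliest report.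

The estimate for compound 4 is 60000 nM, with an expected range of 30000 nM to 100000 nM.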

Compound 4, half-maximal inhibitory concentration: > 50000 nM
Compound 4: only a limit was reported (the forecaster's own chance of this, stated with the estimate: 85%); the middle value lies beyond the limit too.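

In this assay compound 4 gives > 50000 nM as a limit. No new step can be read between compound 4 and compound 1, compound 2 or compound 3, as all four compounds share one ceiling: the limit of > 50000 nM in this assay, at which 4 of the 4 values shown sit.
How far each of these compounds lies beyond that ceiling, and whether the added carboxy changes activity at all, stays open.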